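The source may hold more compounds than are shown below. What is called first, only, known or untested is meant among the compounds shown, and "the series" means these compounds.

Working notes on the series.

Compound 1 `CC1=CCC[C@](C)(CC/C(C)=C/CC2=C(O)C(=O)C=C(N[C@@H](C(=O)O)[C@@H](C)O)C2=O)[C@@H]1C` and compound 2 `CC1=CCC[C@](C)(CC/C(C)=C/CC2=C(O)C(=O)C=C(N[C@H](CO)C(=O)O)C2=O)[C@@H]1C` sit on one core; compound 3 `C=C1[C@H](C)CCC[C@]1(C)CC/C(C)=C/CC1=C(O)C(=O)C=C(N[C@H](C(=O)O)[C@H](C)O)C1=O` and the not yet measured compound 4 `C=C1[C@H](C)CCC[C@]1(C)CC/C(C)=C/CC1=C(O)C(=O)C=C(N[C@@H](CO)C(=O)O)C1=O` sit on a core with the same atoms joined differently, and the difference between the two cores is not broken down here.

In an ADME assay on L1210 cells (Mus musculus) for cytotoxicity, with a stated time of 48 h (a higher number here means a weaker inhibitor, a lower number a stronger inhibitor), compound 1 gives > 10 ug/mL, which is a limit of the assay and not a number. In this assay compound 2 gives > 10 ug/mL, again a limit. In this assay compound 3 gives > 10 ug/mL, also a limit.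

From compound 1 to compound 2 the change is hydrogen in place of methyl on a saturated chain carbon bound to an oxygen on a saturated carbon and a saturated chain carbon. The step it made in this assay, a step that the two limits leave unreadable from compound 1 to compound 2, has no readable size because of the limit of > 10 ug/mL in this assay, at which 3 of the 3 values shown sit.

From compound 3 to compound 4 the change is hydrogen in place of methyl on a saturated chain carbon bound to an oxygen on a saturated carbon and a saturated chain carbon. Its place reads word for word as the place of the change from compound 1 to compound 2, so it is the same change carried onto the core of compound 3.

Compound 4 is to be measured in this assay. The step from compound 3 to compound 4 is expected to be a step that the limit leaves unreadable from compound 3 to compound 4, and this expectation rests on the fact that the same change returned only limits in this assay for compound 1 and compound 2 because of the limit of > 10 ug/mL in this assay, at which 3 of the 3 values shown sit. Compound 4 is therefore estimated to give 15 ug/mL, with a range from 8 ug/mL to 40 ug/mL, most probably reported as a limit again.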

Compound 4, half-maximal inhibitory concentration: > 10 ug/mL
Compound 4: a limit, no number; the forecaster's own chance of this, stated with the estimate: 85%; the middle value lies beyond the limit too.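

In this assay compound 4 gives > 10 ug/mL, which is a limit of the assay and not a number. No step can be read from compound 3 to compound 4, because the new result sits at the same limit as the others: the limit of > 10 ug/mL in this assay, at which 4 of the 4 values shown sit. The compounds shown leave open how large the effect of hydrogen in place of methyl is in this assay on either core.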